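Acetyl on the ring nitrogen and tolerability in Vero cells

The source may hold more compounds than are shown below. What is called first, only, known or untested is meant among the compounds shown, and "the series" means these compounds.

Measured so far in an ADME assay on Vero cells (Chlorocebus sabaeus) for cytotoxicity, read by MTT assay; a higher number here means that more compound is tolerated, a lower number that less compound is tolerated:
Compound 1 `N#Cc1c(N2CCCCC2)n[nH]c1N` gives 550 ug/mL.
Compound 2 `CC(=O)n1nc(N2CCCCC2)c(C#N)c1N` gives 1020 ug/mL.
Compound 3 `N#Cc1c(N2CCCC2)n[nH]c1N` gives 2500 ug/mL.

Compound 2 differs from compound 1 by acetyl in place of hydrogen on an aromatic nitrogen. This change made a 1.9-fold higher number from compound 1 to compound 2 (0.27 log units; within the scatter). Compound 3 carries a different core; the difference between the two cores is not broken down here. Compound 4 `CC(=O)n1nc(N2CCCC2)c(C#N)c1N` is not yet measured; it differs from compound 3 by acetyl in place of hydrogen on an aromatic nitrogen. Among the measured compounds shown here, this is the same kind of change as the one from compound 1 to compound 2, but not the same: in compound 3 the place is two ring bonds from the ring atom that bears a pyrrolidin-1-yl group (5 heavy atoms), whereas in compound 1 it is two ring bonds from the ring atom that bears a group of 6 heavy atoms.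

Because the earlier step of a 1.9-fold higher number from compound 1 to compound 2 (0.27 log units; within the scatter) stayed within the scatter, compound 4 is expected to sit close to compound 3, with an expected step of a 1.4-fold higher number from compound 3 to compound 4 (0.15 log units; within the scatter). Compound 4 is therefore estimated at 3500 ug/mL in this assay, with a range from 1500 ug/mL to 8000 ug/mL.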

Compound 4, half-maximal cytotoxic concentration: 2810 ug/mL
Compound 4: middle estimate off by 1.2-fold (0.10 log units), on the high side; the range from low to high includes it.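

In this assay, acetyl in place of hydrogen on the aromatic nitrogen gave a 1.1-fold higher number from compound 3 to compound 4 (0.05 log units; within the scatter), so on this core, as on the core of compound 1, the two numbers stay within the usual scatter of each other. Set side by side, the two steps cannot be told apart: the same change on two cores in this assay, a 1.9-fold higher number (0.27 log units; within the scatter) from compound 1 to compound 2 and a 1.1-fold higher number (0.05 log units; within the scatter) from compound 3 to compound 4, 1.6-fold (0.22 log units) apart, within the scatter of two such steps. This shows that the change carried over between these two cores without a step large enough to read, but it does not show that acetyl has no effect at all, since a small real shift could stay hidden in the scatter, and two cores cannot establish a rule for the whole series.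

The compounds shown leave open whether a larger group on the same aromatic nitrogen, such as benzoyl or an acyl group with a longer chain, would stay as close to its parent as acetyl does. They also leave open whether the step stays this small when an open-chain amine such as diethylamino takes the place of the pyrrolidin-1-yl group.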